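Swapping the benzyl ring in a sulfonamide-linked diamine series

This account rests on a few compounds, and the source may have more. Where it says the series, first, only, none or still open, it means among the compounds named here.

Of the compounds shown here, three sharing one sulfonamide core have been measured so far. Compound 1 `O=S(=O)(NCCCCNCc1ccc(Br)cc1)c1cc(C(F)(F)F)cc(C(F)(F)F)c1` gives 1900 nM in a functional assay on Capan-2 cells (Homo sapiens) for inhibition, read by MTT assay, with a stated time of 72 h (on this read-out higher numbers stand for weaker inhibition of growth and lower numbers for stronger inhibition of growth), compound 3 `O=S(=O)(NCCCNCc1ccc(Br)cc1)c1cc(C(F)(F)F)cc(C(F)(F)F)c1` gives 2000 nM, and compound 2 `COc1ccc(CNCCCNS(=O)(=O)c2cc(C(F)(F)F)cc(C(F)(F)F)c2)cc1OC` gives 15000 nM. Compound 2 therefore stands at the highest number of the three, meaning the weakest growth inhibition; its nearest neighbour is compound 3, and the gap between them is beyond the scatter, while a 1.1-fold higher number from compound 1 to compound 3 (0.02 log units; within the scatter).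

Compound 4 `O=S(=O)(NCCCNCc1ccc(Cl)cc1)c1cc(C(F)(F)F)cc(C(F)(F)F)c1` has not yet been measured. Its difference from compound 2 is 4-chlorophenyl in place of 3,4-dimethoxyphenyl on a saturated chain carbon bound to an amine nitrogen.

Within the data shown here, one measured step bears directly on this: a 7.5-fold lower number from compound 2 to compound 3 (0.88 log units; beyond the scatter). That step exchanged the same dimethoxyphenyl for a bromophenyl, a halogen on the same ring. Compound 4 carries a chlorophenyl instead, so a step of similar size and direction is expected, though whether chlorine matches bromine exactly cannot be told from these three compounds alone.

The estimate for compound 4 is therefore 2500 nM, with a range from 1000 nM to 6500 nM, which amounts to an expected 6.0-fold lower number from compound 2 to compound 4 (0.78 log units; beyond the scatter).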

Compound 4, concentration for 50% growth inhibition: 2700 nM
The estimate for compound 4 lay 1.1-fold (0.03 log units) below the measured number; measured number inside the range.
By their numbers in this assay, from the lowest: compounds 1, 3 and 4 (each within the scatter of the next); then compound 2.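

In this assay, a 5.6-fold lower number from compound 2 to compound 4 (0.74 log units; beyond the scatter) shows that the shift away from compound 2 seen earlier with bromo on the ring also occurs with a different halogen, so at this position it does not depend on bromo alone. Chloro in place of bromo on an aromatic carbon gives a 1.4-fold higher number from compound 3 to compound 4 (0.13 log units; within the scatter), and a 1.4-fold higher number from compound 1 to compound 4 (0.15 log units; within the scatter), a comparison in which the chain differs as well as the halogen; neither step can separate these compounds, so compound 2 remains the only one that stands apart from the others. No measurement shown here explains why the 3,4-dimethoxybenzyl compound differs from the halogen-bearing compounds.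

From the compounds shown here alone, what remains open is whether the lower numbers come from having a halogen on the ring or simply from not having both methoxy groups, a question that an unsubstituted phenyl ring or a ring with a single methoxy group could help answer. Going by these compounds, it is also open whether the pattern extends to other groups on this ring, such as fluoro or nitrile.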